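A few compounds are considered here, and "the series" means these few. Any claim that something is new, unique, unknown or untested is made for them only; others in the source may bear on it.

Working notes on the series.

Three compounds have numbers in a functional assay on the whole organism for inhibition, with Rattus norvegicus as the target, with stated times of 1 h and 3.5 h, at a dose of 100 mg/kg by the oral route; a higher number here means more inhibition at the dose given (going by the name of the read-out), a lower number less inhibition. Compound 1 `Cc1cncnc1-c1ccccc1` gives 48% in this assay. Compound 2 `CC(=O)Nc1nccc(-c2ccncc2)n1` gives 52% in this assay. Compound 3 `CC(C)(C)c1ncncc1-c1ccccc1` gives 48% in this assay. Compound 3 stands level with compound 1 at the digits shown, and the number for compound 2 is slightly higher, within the usual scatter; the three numbers therefore sit together, and none of them is set apart from the others beyond the scatter.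

The next compound is compound 4 `CNc1ncc(-c2ccccc2)c(C(C)(C)C)n1`, not yet measured in this assay. It differs from compound 3 in one place: methylamino in place of hydrogen on an aromatic carbon

For the measured compounds named here, no step between measured compounds is available to guide this change. The numbers in hand are all of one size across three different cores and substituents, so the step from compound 3 to compound 4 is expected to be small, a number 2 percentage points higher from compound 3 to compound 4 (within the scatter), without a clear direction beyond the scatter. Compound 4 is accordingly estimated at 50% in this assay, with a range from 33% to 67%.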

Compound 4, a percentage reported as inhibition, in the whole organism at one dose (the size of the read-out at that dose, not a potency): 37%
Beside the measured number, compound 4's estimate is 13 percentage points above it, and the stated range covers the measured number.
By their numbers in this assay, from the lowest: compound 4; then compounds 1, 3 and 2 (each within the scatter of the next).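

In this assay, for the compounds shown here, this position is not silent: methylamino in place of hydrogen on an aromatic carbon, between two ring nitrogen atoms, gives a number 11 percentage points lower from compound 3 to compound 4 (beyond the scatter) and is the first step that can be read. Going by these compounds alone, the earlier compounds offered no step, so it is only here that substitution at this place is seen to change the inhibition at the dose given, and the one change seen lowers it modestly. Nothing measured on these compounds bears on the origin of this step.

As far as these compounds go, whether the drop belongs to methylamino in particular stays open, since a plain amino group, a dimethylamino group or a methoxy group at this place could behave differently. Also open, from the compounds shown here alone, is whether the same change on the core of compound 1 would give a step of like size.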